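From Ester to Anilide on the Shared Core

A few compounds are considered here, and "the series" means these few. Any claim that something is new, unique, unknown or untested is made for them only; others in the source may bear on it.

Compound 3 `CCOC(=O)CC(C)OC(=O)c1ccc(C(CC)(CC)c2ccc(OCC(=O)C(C)(C)C)c(C)c2)n1CC` stands only at a limit: in an assay on HL-60 cells for agonist activity at vitamin D3 receptor (Homo sapiens), read by microscopy, with a stated time of 96 h (on this read-out higher numbers stand for an effect only at larger amounts of compound and lower numbers for an effect already at smaller amounts), compound 3 gives > 50000 nM, a limit of the assay rather than a number. Compound 4 `CCn1c(C(=O)Nc2ccc(OC(F)(F)F)cc2)ccc1C(CC)(CC)c1ccc(OCC(=O)C(C)(C)C)c(C)c1` carries a group of 12 heavy atoms (7 carbon, 1 nitrogen, 1 oxygen, 3 fluorine; one six-membered aromatic ring of carbon only) in place of a group of 9 heavy atoms (6 carbon, 3 oxygen; no ring), on a carbonyl carbon. Within the data shown here, one measured step bears on this change. Compound 2 `CCn1c(C(=O)NCC(OC)OC)ccc1C(CC)(CC)c1ccc(OCC(=O)C(C)(C)C)c(C)c1` holds an amide bearing one hydrogen-bond donor on the same carbonyl carbon, and in this assay compound 2 gives 130 nM. The step of an at least 380-fold higher number from compound 2 to compound 3 (2.58 log units; beyond the scatter) is large. Compound 1 `CCOC(=O)CN(C)C(=O)c1ccc(C(CC)(CC)c2ccc(OCC(=O)C(C)(C)C)c(C)c2)n1CC` gives > 50000 nM, again a limit. The step that the two limits leave unreadable from compound 1 to compound 3 cannot be sized, as the limit of > 50000 nM in this assay, at which 2 of the 3 values shown sit, shows. Because the step of an at least 380-fold higher number from compound 2 to compound 3 (2.58 log units; beyond the scatter) was large and the entering group again carries one hydrogen-bond donor, compound 4 is expected to show a large downward step, an at least 200-fold lower number from compound 3 to compound 4 (2.30 log units; beyond the scatter). Compound 4 is estimated at 250 nM, within 30 nM to 4000 nM.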

Compound 4, half-maximal effective concentration: > 50000 nM
Compound 4: no number, only a limit; the forecaster's own chance of this, stated with the estimate: 20%; middle value at least 200-fold (2.30 log units) away from the limit.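

On this carbonyl carbon, the hydrogen-bond donor does not by itself carry the result: compound 4 shares it with compound 2, yet the change gives an at least 380-fold higher number from compound 2 to compound 4 (2.58 log units; beyond the scatter) in this assay. The entry for compound 4 is a limit, not a number. The steps joining compound 1 and compound 3 to compound 4 cannot be read, as all of them end at the same limit: the limit of > 50000 nM in this assay, at which 3 of the 4 values shown sit.

Going by these compounds, it stays open whether a 2-methoxyethyl chain or a benzyl group on the amide-type nitrogen would give a measurable number in this assay. Which part of 2,2-dimethoxyethyl goes with the number of compound 2 also stays open.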